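Swapping the Bromophenyl Arm for a Thiophene Ring

This account rests on a few compounds, and the source may have more. Where it says the series, first, only, none or still open, it means among the compounds named here.

Compound 2 `Brc1ccc(-c2cn3ccnc3c(-c3ccc4ncn(C5CCCCC5)c4c3)n2)cc1` stands lowest of the two numbers measured in a functional assay on MDA-MB-468 cells (Homo sapiens) for inhibition, read by sulforhodamine B assay, with a stated time of 48 h, tested at 10 uM (on this read-out lower numbers stand for less inhibition and higher numbers for more inhibition at the one concentration tested (going by the name of the read-out)), where compound 2 gives 33.7%. Its neighbour, compound 1 `c1ccc(-c2cn3ccnc3c(-c3ccc4ncn(C5CCCCC5)c4c3)n2)cc1`, gives 54.4% in this assay. Compound 3 `c1csc(-c2cn3ccnc3c(-c3ccc4ncn(C5CCCCC5)c4c3)n2)c1` differs from compound 2 in one place: thiophen-2-yl in place of 4-bromophenyl on an aromatic carbon. For the measured compounds named here, no measured step exchanges one aromatic ring for another; the only step, a number 20.7 percentage points lower from compound 1 to compound 2 (beyond the scatter), shows that adding bromo cost inhibition. Removing the bromine-bearing ring may therefore recover some of that loss, so compound 3 is expected to show a number 14.3 percentage points higher from compound 2 to compound 3 (beyond the scatter), giving an estimated 48%, between 25% and 70%.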

Compound 3, a percentage reported as inhibition, at one concentration (the size of the read-out at that concentration, not a potency): 15.1%
The estimate for compound 3 lay 32.9 percentage points above the measured number; the measured number lies below the stated range.
By their numbers in this assay, from the lowest: compound 3; then compound 2; then compound 1.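

In this assay the thiophen-2-yl group gives a number 18.6 percentage points lower from compound 2 to compound 3 (beyond the scatter) and a number 39.3 percentage points lower from compound 1 to compound 3 (beyond the scatter) in the second comparison with the phenyl group. Taking away the 4-bromophenyl ring therefore recovers no inhibition, and the number at this position moves with the aromatic ring itself, not only with a bromo group added to phenyl. No available evidence explains this drop. From the compounds shown here alone, whether a phenyl ring carrying an amine or a carboxylic acid would raise the number here remains open, as does the effect of a pyridine ring.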